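Swapping the Distal Aryl Group and Cytotoxicity

The compounds below may be only part of what the source reports. "The series", "measured", "known", "first", "only" and "open" are said of these compounds alone.

Measured so far in an ADME assay on MT4 cells (Homo sapiens) for cytotoxicity, read by MTT assay, with a stated time of 4 days; on this read-out higher numbers stand for lower toxicity in this test and lower numbers for higher toxicity in this test:
- compound 1, `Cc1ccc(-c2cc(C)c(Nc3ccnc(Nc4ccc(C#N)cc4)n3)c(C)c2)cc1`: 5570 nM
- compound 2, `Cc1cc(-c2ccc(C(F)(F)F)cc2)cc(C)c1Nc1ccnc(Nc2ccc(C#N)cc2)n1`: 4160 nM
- compound 3, `Cc1cc(-c2ccc(F)cc2)cc(C)c1Nc1ccnc(Nc2ccc(C#N)cc2)n1`: 4170 nM

Compound 1 gives the highest of the three numbers, but its gap to compound 3, a 1.3-fold lower number from compound 1 to compound 3 (0.13 log units; within the scatter), and its gap to compound 2, a 1.3-fold lower number from compound 1 to compound 2 (0.13 log units; within the scatter), both sit within the scatter, so the three compounds cannot be told apart on this read-out. The step between compound 2 and compound 3, a 1.0-fold higher number from compound 2 to compound 3 (0.00 log units; within the scatter), is likewise within the scatter.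

The compound still to be measured is compound 4, `Cc1cc(-c2cccc(C#N)c2)cc(C)c1Nc1ccnc(Nc2ccc(C#N)cc2)n1`. It differs from compound 1 in one place: 3-cyanophenyl in place of 4-methylphenyl on an aromatic carbon

Two earlier steps changed a group on the same outer ring of the shared core: trifluoromethyl in place of methyl, a 1.3-fold lower number from compound 1 to compound 2 (0.13 log units; within the scatter), and fluoro in place of methyl, a 1.3-fold lower number from compound 1 to compound 3 (0.13 log units; within the scatter). Neither moved the number beyond the scatter. The present change replaces the whole 4-methylphenyl with 3-cyanophenyl, bringing in a nitrile, which is a larger change than either earlier one, so the precedent is only partial. Among the compounds with values here, still, with no step in this set reaching beyond the scatter, the expectation for compound 4 is a step of a 1.2-fold lower number from compound 1 to compound 4 (0.06 log units; within the scatter), that is, none beyond the scatter. Compound 4 is therefore estimated at 4800 nM, with a range of 2400 nM to 9600 nM.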

Compound 4, half-maximal cytotoxic concentration: 920 nM
Beside the measured number, compound 4's estimate is 5.2-fold (0.72 log units) above it; measured number outside the range, below it.
By their numbers in this assay, from the lowest: compound 4; then compounds 2, 3 and 1 (each within the scatter of the next).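

At this position of the shared core, the outer ring is not interchangeable in this assay: 3-cyanophenyl gives a 6.1-fold lower number from compound 1 to compound 4 (0.78 log units; beyond the scatter) and also a 4.5-fold lower number from compound 3 to compound 4 (0.66 log units; beyond the scatter) and a 4.5-fold lower number from compound 2 to compound 4 (0.66 log units; beyond the scatter) when set against the other two rings, where a lower number stands for higher toxicity in this test. The 4-methylphenyl, 4-fluorophenyl and 4-(trifluoromethyl)phenyl compounds stay within the scatter of one another, so compound 4 is the first of these compounds to show that a change here can move this read-out beyond the scatter, although the nitrile and its place on the ring change together in this swap. Nothing available here accounts for this shift.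

The compounds shown cannot separate the effect of the nitrile itself from the effect of where it sits on the outer ring, since no other compound carries a nitrile on that ring. Nor do they show whether an amine, a carboxylic acid or a methoxy group on the same ring would leave the number with the first three compounds or take it toward compound 4.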